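Fluorine for Hydrogen on the Side Chain of Compound 1

This account rests on a few compounds, and the source may have more. Where it says the series, first, only, none or still open, it means among the compounds named here.

Compound 1, `COc1cc(C(c2ccc(O)c(OC)c2)[C@@H](C)C(C)C)ccc1O`: 20000 nM
Compound 2, `COc1ccc(C(c2ccc(OC)c(OC)c2)[C@@H](C)[C@H](C)CO)cc1OC`: > 100000 nM
Compound 3, `COc1ccc(C(c2ccc(OC)c(OC)c2)[C@@H](C)[C@@H](C)CO)cc1OC`: > 100000 nM

All three were tested in a functional assay on HL-60 cells (Homo sapiens) for cytotoxicity, read by WST assay, with a stated time of 48 h; on this read-out lower numbers stand for stronger inhibition and higher numbers for weaker inhibition. For the measured compounds named here, compound 1 gives 20000 nM, the only actual number among them. For compound 2 the read-out > 100000 nM is a limit of the assay, not a number. For compound 3 the read-out > 100000 nM is likewise a limit. The step that the two limits leave unreadable from compound 2 to compound 3 therefore cannot be read, since the fact that compounds 2 and 3 differ only in the configuration as drawn is all the pair shows. Compound 4, `COc1cc(C(c2ccc(O)c(OC)c2)[C@@H](C)[C@H](C)CF)ccc1O`, is not yet measured. It differs from compound 1 by fluoro in place of hydrogen on a saturated chain carbon, four bonds along the chain from two aromatic carbons. No measured step bears on this change, and the one step shown is unreadable because of the limit of > 100000 nM in this assay, at which 2 of the 3 values shown sit. No step beyond the scatter is therefore expected; the estimated step is no change at the digits printed from compound 1 to compound 4 (within the scatter). Compound 4 is expected at 20000 nM, between 8000 nM and 50000 nM.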

Compound 4, half-maximal inhibitory concentration: 32000 nM
The estimate for compound 4 lay 1.6-fold (0.20 log units) below the measured number, and the stated range covers the measured number.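

In this assay, fluoro in place of hydrogen on this saturated chain carbon gives a 1.6-fold higher number from compound 1 to compound 4 (0.20 log units; within the scatter). For the compounds shown here, this position therefore takes a single fluorine atom without moving the number beyond the usual scatter, and this is the first readable step on this side chain. The earlier step between two stereoisomers cannot be read: the limit of > 100000 nM in this assay, at which 2 of the 4 values shown sit.

As far as these compounds go, what an amine or a carboxylic acid on this same chain carbon would do in this assay stays open. So does whether the opposite configuration at this carbon, carrying fluoro, would give a similar number.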